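Replacing the pyridine on compound 1

This account rests on a few compounds, and the source may have more. Where it says the series, first, only, none or still open, it means among the compounds named here.

Among the measured compounds shown here, in an ADME assay on J744 cells (Mus musculus) for cytotoxicity, read by MTT assay, with a stated time of 48 h (a lower number here means a stronger inhibitor, a higher number a weaker inhibitor), compound 1 `O=C(N/N=C/c1ccc2no[n+]([O-])c2c1)c1cccnc1` gives 31000 nM, the only exact number so far. Compound 2 `Cc1c(C(=O)N/N=C/c2ccc(C(=O)O)cc2)no[n+]1[O-]` gives only a limit, > 400000 nM. Compound 3 `Cc1[nH]cnc1C(=O)N/N=C/c1ccc2no[n+]([O-])c2c1` keeps the core of compound 1 and carries 5-methyl-1H-imidazol-4-yl in place of pyridin-3-yl on a carbonyl carbon. For the measured compounds named here, no measured step covers this change. The expected 1.5-fold higher number from compound 1 to compound 3 (0.16 log units; within the scatter) in this assay is none beyond the scatter, with no firm direction. For compound 3 the estimated value is 45000 nM, with an expected range of 13000 nM to 160000 nM.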

Compound 3, half-maximal inhibitory concentration: 38000 nM
Beside the measured number, compound 3's estimate is 1.2-fold (0.07 log units) above it; measured number inside the range.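

Among the compounds shown here, on a carbonyl carbon, the only measured step shows 5-methyl-1H-imidazol-4-yl standing in place of pyridin-3-yl with a 1.2-fold higher number from compound 1 to compound 3 (0.09 log units; within the scatter) in this assay. On this core, a five-membered aromatic ring carrying a hydrogen-bond donor thus reads out the same as the six-membered ring within the scatter. Nothing shown bears on a cause for this step. Still open, going by these compounds, is whether an aliphatic amine or a longer alkyl chain at this place would move the number beyond the scatter.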